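Thiophene for pyridine on the shared core: expected cytotoxicity

The source may hold more compounds than are shown below. What is called first, only, known or untested is meant among the compounds shown, and "the series" means these compounds.

Measured so far:
- compound 1 `Oc1ccc(-c2cc(-c3ccc(Cl)cc3)nc(-c3cccnc3)c2)cc1`: 22800 nM
- compound 2 `Oc1cccc(-c2cc(-c3ccncc3)nc(-c3cccc(Cl)c3)c2)c1`: "not determined" (no result reported)
- compound 3 `Oc1ccc(-c2cc(-c3ccco3)nc(-c3ccccc3Cl)c2)cc1`: 5300 nM

Working notes. In a functional assay on DU-145 cells (Homo sapiens) for cytotoxicity, read by CCK-8 assay and cell counting, with a stated time of 2 days (on this read-out higher numbers stand for weaker inhibition and lower numbers for stronger inhibition), compound 1 gives 22800 nM. For the measured compounds named here, in the same assay compound 3 gives 5300 nM; these two compounds differ in several places at once, so their values show only that compound 3 returns the lower number. Compound 2 carries a pyridin-4-yl group together with a 3-hydroxyphenyl group and a 3-chlorophenyl group, and for compound 2 this assay gives "not determined" (no result reported); no single number is available, so compound 2 cannot be placed against compound 1 or compound 3.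

Compound 4 `Oc1cccc(-c2cc(-c3ccsc3)nc(-c3cccc(Cl)c3)c2)c1` is not yet measured. Relative to compound 2 the change is thiophen-3-yl in place of pyridin-4-yl on an aromatic carbon. Without a number for compound 2, the step from compound 2 to compound 4 cannot be sized from the data. Going by the values given here, the only anchors are compound 1 and compound 3, the latter carrying a five-membered heteroaryl group like compound 4.

Compound 4 is expected to fall near the value of compound 3, with an estimate of 8000 nM and a range from 2500 nM to 30000 nM.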

Compound 4, half-maximal inhibitory concentration: 3330 nM
Beside the measured number, compound 4's estimate is 2.4-fold (0.38 log units) above it; measured number inside the range.
By their numbers in this assay, from the lowest: compounds 4 and 3 (each within the scatter of the next); then compound 1.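

No new step can be read: compound 2 has no single number in this assay and compound 4 at 3330 nM therefore cannot be set against it, while compound 1 and compound 3 differ from compound 4 in several places. No measured property bears on this result. As far as these compounds go, what thiophen-3-yl in place of pyridin-4-yl does to the read-out on the shared core stays open.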